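The source may hold more compounds than are shown below. What is called first, only, known or untested is meant among the compounds shown, and "the series" means these compounds.

Working notes on the series. The shared core of compound 1 `Cc1ccc(-c2c(S(=O)(=O)c3ccccc3)cnc3cc(C)nn23)cc1` carries a methyl on the five-membered ring and a methyl on the pendant phenyl. In a functional assay on the whole organism for inhibition, with Mus musculus as the target, with a stated time of 6 h, at a dose of 50 mg/kg by the oral route (a lower number here means less inhibition, a higher number more inhibition at the dose given (going by the name of the read-out)), compound 1 gives 8.7%. Compound 2 `Cc1cc2ncc(S(=O)(=O)c3ccccc3)c(-c3ccc(Br)cc3)n2n1` has bromo in place of methyl on the pendant phenyl and in this assay compound 2 gives 0%. Of the two numbers compound 1 stands as the one not at zero, but the step of a number 8.7 percentage points lower from compound 1 to compound 2 (within the scatter) is within the scatter, so the two compounds are not separated.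

Compound 3 `Cc1ccc(-c2c(S(=O)(=O)c3ccccc3)cnc3cc(-c4ccc(Br)cc4)nn23)cc1` is not yet measured. The change from compound 1 is 4-bromophenyl in place of methyl on an aromatic carbon. Going by the values given here, no measured step touches that position on the five-membered ring; the only step available, a number 8.7 percentage points lower from compound 1 to compound 2 (within the scatter), concerns the pendant phenyl and was within the scatter. Both measured compounds sit near the bottom of the scale, so a step beyond the scatter in this assay is not expected, in either direction. Compound 3 is therefore estimated at 10%, with a range of 0% to 35%, which means an expected step of a number 1.3 percentage points higher from compound 1 to compound 3 (within the scatter).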

Compound 3, a percentage reported as inhibition, in the whole organism at one dose (the size of the read-out at that dose, not a potency): 54.3%
Compound 3: the middle estimate sits 44.3 percentage points below what was measured; the whole stated range lies below it.
By their numbers in this assay, from the lowest: compounds 2 and 1 (each within the scatter of the next); then compound 3.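

In this assay, going by these compounds alone, the replacement of methyl by 4-bromophenyl on an aromatic carbon of the five-membered aromatic ring gives a number 45.6 percentage points higher from compound 1 to compound 3 (beyond the scatter) and is the only step so far to lie beyond the scatter. The other step available, a number 8.7 percentage points lower from compound 1 to compound 2 (within the scatter), is the swap of methyl for bromo on the pendant phenyl and stays within the scatter, so this position on the five-membered ring is the one place shown where a change separates compounds in this read-out. Nothing measured on these compounds speaks to the reason for the step.

Within the data shown here, the single pair cannot separate the contribution of the added six-membered aromatic ring from that of its bromine, and an unsubstituted phenyl or a 4-methoxyphenyl on the same carbon would address this. Also open, from the compounds shown here alone, are whether a longer alkyl chain or an amine at this position gives a comparable number, and whether the step holds when the pendant phenyl carries bromo in place of methyl.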